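Chloro to hydrogen on the pendant phenyl of compound 1

This account rests on a few compounds, and the source may have more. Where it says the series, first, only, none or still open, it means among the compounds named here.

Measured compounds:
compound 1 `COc1cc(/C=C/C(=O)c2cccc(-n3cc(-c4ccc(Cl)cc4)[nH]c3=O)c2)cc(OC)c1OC`: 7170 nM
compound 2 `COc1cc(/C=C/C(=O)c2cccc(-n3cc(-c4ccccc4)[nH]c3=O)c2)ccc1O`: 2500 nM
compound 3 `O=C(/C=C/c1cccc(O)c1)c1cccc(-n2cc(-c3ccccc3)[nH]c2=O)c1`: 2760 nM

In a functional assay on ACHN cells (Homo sapiens) for inhibition (a higher number here means a weaker inhibitor of growth, a lower number a stronger inhibitor of growth), compound 1 gives 7170 nM, the highest of the three numbers. Compound 3 stands nearest at 2760 nM and compound 2 furthest at 2500 nM; both gaps to compound 1 lie beyond the scatter.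

Compound 4 `COc1cc(/C=C/C(=O)c2cccc(-n3cc(-c4ccccc4)[nH]c3=O)c2)cc(OC)c1OC` differs from compound 1 by hydrogen in place of chloro on an aromatic carbon. Among the measured compounds shown here, the only measured step, a 1.1-fold higher number from compound 2 to compound 3 (0.04 log units; within the scatter), concerns the aryl on the double-bonded chain and leaves the chloro-bearing ring untouched, so it does not bear on this change. Compounds 2 and 3 carry the unsubstituted phenyl that compound 4 carries, and both give lower numbers than compound 1, yet each also differs from compound 1 in the aryl on the chain; their values therefore do not isolate the chloro-to-hydrogen change. For the measured compounds named here, no direct precedent exists, and the expected step of a 1.6-fold lower number from compound 1 to compound 4 (0.20 log units; within the scatter) is uncertain in direction, with a lean toward a lower number. For compound 4 a value of 4500 nM is expected, within 1500 nM to 13000 nM.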

Compound 4, concentration for 50% growth inhibition: 1600 nM
For compound 4 the middle estimate is 2.8-fold (0.45 log units) above the measured one, within the range that was stated.
By their numbers in this assay, from the lowest: compounds 4, 2 and 3 (each within the scatter of the next); then compound 1.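

In this assay, the step at this position reads a 4.5-fold lower number from compound 1 to compound 4 (0.65 log units; beyond the scatter), with the aryl on the chain held constant. Among the compounds shown here, this is the first matched reading of the pendant phenyl, as the earlier step between compounds changed only the aryl on the chain. The change from 4-chlorophenyl to phenyl therefore lowers the number beyond the scatter for this pair, although one pair sets no trend, and no measurement available here accounts for the step.

The compounds shown leave open whether the same step would appear with the chain aryls of compound 2 and compound 3, since neither has a 4-chlorophenyl partner here. They also leave open how a fluoro, methoxy or amine group at this position would compare with hydrogen and chloro.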